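Solubility Step From an Oxadiazolone to a Triazolylmethyl Group

This account rests on a few compounds, and the source may have more. Where it says the series, first, only, none or still open, it means among the compounds named here.

Measured compounds:
compound 1, `CC(C)C(/C=C1\CCNC1=O)c1ccc(-c2ccc3cccc(F)c3c2)[nH]c1=O`, 20700 nM
compound 2, `CC(C)C(c1noc(=O)[nH]1)c1ccc(-c2ccc3cccc(F)c3c2)[nH]c1=O`, 32500 nM

Of the compounds shown here, two have been measured in a physicochemical assay for solubility, in phosphate buffer, measured as kinetic solubility; a lower number here means a less soluble compound, a higher number a more soluble compound. Compound 1 `CC(C)C(/C=C1\CCNC1=O)c1ccc(-c2ccc3cccc(F)c3c2)[nH]c1=O` gives 20700 nM, and compound 2 `CC(C)C(c1noc(=O)[nH]1)c1ccc(-c2ccc3cccc(F)c3c2)[nH]c1=O` gives 32500 nM. Going by the values given here, the single step between them, a 1.6-fold higher number from compound 1 to compound 2 (0.20 log units; within the scatter), exchanges one five-membered ring for another on the saturated chain carbon, and it falls within the scatter. Compound 2 thus stands at the higher of the two numbers, but its gap to compound 1 is not a real difference.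

Compound 3 `CC(C)C(Cc1nnc[nH]1)c1ccc(-c2ccc3cccc(F)c3c2)[nH]c1=O` is not yet measured. It differs from compound 2 in one place: a group of 6 heavy atoms (3 carbon, 3 nitrogen; one five-membered aromatic ring with 3 hetero atoms) in place of a group of 6 heavy atoms (2 carbon, 2 nitrogen, 2 oxygen; one five-membered aromatic ring with 3 hetero atoms), on a saturated chain carbon bound to an aromatic carbon and a saturated chain carbon. Among the compounds with values here, no measured step reproduces this change; the step from compound 1 to compound 2 is the only one in hand, and it shows that swapping the group on this chain carbon left the solubility within the scatter. On that basis the same is expected here, with no step beyond the scatter in either direction, a 1.1-fold higher number from compound 2 to compound 3 (0.03 log units; within the scatter). Compound 3 is estimated at 35000 nM, in the range 15000 nM to 80000 nM.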

Compound 3, solubility: 24200 nM
Compound 3: the middle estimate sits 1.4-fold (0.16 log units) above what was measured; measured number inside the range.
By their numbers in this assay, from the lowest: compounds 1, 3 and 2 (each within the scatter of the next).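

The exchange of the oxygen-containing aromatic ring for (4H-1,2,4-triazol-3-yl)methyl at this saturated chain carbon gives, in this assay, a 1.3-fold lower number from compound 2 to compound 3 (0.13 log units; within the scatter), while the same group in place of the non-aromatic ring of compound 1 gives a 1.2-fold higher number from compound 1 to compound 3 (0.07 log units; within the scatter). Going by these compounds alone, the earlier compounds offered only one exchange at this place, whereas there are now three groups, all within the scatter of one another, and the result extends this to a swap between two five-membered aromatic rings with 3 hetero atoms that differ in their atoms. No measurement is at hand that would explain why these steps stay so small.

All three groups are neutral five-membered rings with hydrogen-bond donors and acceptors, so the compounds shown leave open whether a group of another kind on this saturated chain carbon, such as a carboxylic acid, a primary amine or a plain longer alkyl chain, would give a step beyond the scatter. They also leave open whether the shared core, rather than the group at this place, sets the level of these numbers, as every compound shown carries the same core.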